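Carbonyl substituent swap: compound 1 to compound 3

The compounds below may be only part of what the source reports. "The series", "measured", "known", "first", "only" and "open" are said of these compounds alone.

- compound 1 `C[C@H](NC(=O)CC(F)(F)F)c1ccc(NC(=O)[C@H]2C[C@@H]2c2cccnc2)cc1` value 41000 nM
- compound 2 `C[C@H](NC(=O)C1CCOCC1)c1ccc(NC(=O)[C@H]2C[C@@H]2c2cccnc2)cc1` value 90000 nM

In a physicochemical assay for solubility, at pH 6.8 (on this read-out higher numbers stand for higher solubility and lower numbers for lower solubility), compound 1 gives 41000 nM as the lower of the two values in hand, and compound 2 gives 90000 nM as the higher. Compound 3 `C[C@H](NC(=O)c1ccccn1)c1ccc(NC(=O)[C@H]2C[C@@H]2c2cccnc2)cc1` has no value yet. Its change from compound 1 is pyridin-2-yl in place of 2,2,2-trifluoroethyl on a carbonyl carbon in short, pyridin-2-yl in place of 2,2,2-trifluoroethyl on a carbonyl carbon.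

For the measured compounds named here, one measured step bears on this, at the same place: the modest 2.2-fold higher number from compound 1 to compound 2 (0.34 log units; beyond the scatter) with oxan-4-yl in place of 2,2,2-trifluoroethyl on a carbonyl carbon. Going by the values given here, that single step has a different entering group, and no measured compound carries pyridin-2-yl here, so it is a weak guide.

In this assay a small rise is expected, most likely within the scatter and probably no larger than that measured step. The estimated step is a 1.3-fold higher number from compound 1 to compound 3 (0.13 log units; within the scatter) in the same direction as the measured one. For compound 3 the expected value is 55000 nM with an estimated range from 18000 nM to 130000 nM at its two ends.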

Compound 3, solubility: 10000 nM
Compound 3: the middle estimate sits 5.5-fold (0.74 log units) above what was measured; measured number below the stated range.
By their numbers in this assay, from the lowest: compound 3; then compound 1; then compound 2.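

In this assay the substituent on this carbonyl carbon can now move the number in either direction: oxan-4-yl in place of 2,2,2-trifluoroethyl gave a 2.2-fold higher number from compound 1 to compound 2 (0.34 log units; beyond the scatter), whereas pyridin-2-yl in the same place gives a 4.1-fold lower number from compound 1 to compound 3 (0.61 log units; beyond the scatter) and so reverses the sign of the change. Against the other ring at this position, pyridin-2-yl gives a 9.0-fold lower number from compound 2 to compound 3 (0.95 log units; beyond the scatter), the largest step among the three compounds, which shows that two ring substituents at this carbonyl carbon need not read alike and leaves compound 3 lowest of the set, with both of its steps beyond the scatter. Nothing in hand accounts for the fall or for the gap between the two ring substituents.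

With a single aromatic ring at this position, the compounds do not separate the contribution of the ring from that of its nitrogen, and phenyl or pyridin-3-yl on the same carbonyl carbon would bear on that question. On these data alone, how a saturated ring carrying an amine, such as piperidin-4-yl, or a carboxylic acid on a short chain would read here also remains open.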